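A Thiadiazole in Place of an Oxadiazole

The source may report more compounds than this note shows. Statements on the series, on what has been measured and on what is new or still open speak of the compounds shown alone.

Compound 1 `Cc1nnc(SCc2cc(=O)c3cc(Cl)ccc3o2)o1` was tested in a functional assay on MDA-MB-435S cells (Homo sapiens) for cytotoxicity, read by MTT assay, with a stated time of 72 h; on this read-out lower numbers stand for stronger inhibition and higher numbers for weaker inhibition. In this assay compound 1 gives > 25000 nM, which is a limit of the assay rather than a number. Two related compounds were run alongside it. Compound 2 `Cc1nnc(SCc2cc(=O)c3ccccc3o2)o1` also reaches only a limit in this assay, where compound 2 gives > 25000 nM. For the measured compounds named here, compound 3 `Cc1nnc(SCc2coc3ccccc3c2=O)o1` is the one compound with a read number: in this assay compound 3 gives 1200 nM. The single step that can be traced among these three, a step that the two limits leave unreadable from compound 1 to compound 2, joins two limits and so says nothing readable about size. The picture is summed up by the limit of > 25000 nM in this assay, at which 2 of the 3 values shown sit.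

Compound 4 `Cc1nnc(SCc2cc(=O)c3cc(Cl)ccc3o2)s1` differs from compound 1 in one place: 5-methyl-1,3,4-thiadiazol-2-yl in place of 5-methyl-1,3,4-oxadiazol-2-yl on a sulfur. Going by the values given here, no measured step among compound 1, compound 2 and compound 3 touches this part of the molecule, so nothing here points to a direction for the change in this assay. The starting point itself is only a limit, which further blurs any forecast. The step that the limit leaves unreadable from compound 1 to compound 4 is therefore expected to be small, with the outcome most likely again beyond the limit. Compound 4 is estimated at 30000 nM, within a range from 5000 nM to 100000 nM.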

Compound 4, half-maximal inhibitory concentration: > 25000 nM
Compound 4: a limit, no number; the forecaster's own chance of this, stated with the estimate: 70%; the middle value lies beyond the limit too.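

Compound 1 and compound 4 both end at a limit of this assay rather than at a number, so the step between them cannot be read. The overall picture remains: the limit of > 25000 nM in this assay, at which 3 of the 4 values shown sit. The compounds shown leave open whether 5-methyl-1,3,4-thiadiazol-2-yl in place of 5-methyl-1,3,4-oxadiazol-2-yl on a sulfur changes cytotoxicity at all.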